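The source may report more compounds than this note shows. Statements on the series, on what has been measured and on what is new or still open speak of the compounds shown alone.

The measured compounds so far:
compound 1, `CCN(CC)CCCOc1cc(OC)ccc1-c1cc(-c2ccccc2)no1`, which in a functional assay on the whole organism (blood, strain Sprague-Dawley albino) with Rattus norvegicus as the target, with stated times of 30 min and 5 h, at a dose of 100 mg/kg by the oral route (a higher number here means more inhibition at the dose given (going by the name of the read-out), a lower number less inhibition), gives 7.8%;
compound 2, `COc1ccc(-c2cc(-c3ccccc3)no2)c(OCCCN2CCCC2)c1`, which gives 13.4%.

Among the compounds with values here, compound 1 holds the lower of the two numbers, but the only step that places it, a number 5.6 percentage points higher from compound 1 to compound 2 (within the scatter), stays within the scatter, so the two compounds cannot be told apart on these readings. Both sit at the low end of the inhibition scale.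

Compound 3, `CCCCN(C)CCCOc1cc(OC)ccc1-c1cc(-c2ccccc2)no1`, has not yet been measured. It differs from compound 1 by butyl(methyl)amino in place of diethylamino on a saturated chain carbon, three bonds along the chain from an oxygen on an aromatic ring. Within the data shown here, the one measured step that bears on this change is the exchange of one amine for another at the same place on the chain, a number 5.6 percentage points higher from compound 1 to compound 2 (within the scatter), and that step did not rise above the scatter. On this basis there is nothing to suggest that a third amine at the same place would move the read-out by more than the scatter, and the step of a number 2.2 percentage points higher from compound 1 to compound 3 (within the scatter) is expected to be small. Compound 3 is therefore estimated to give 10%, with a range from 0% to 22%.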

Compound 3, a percentage reported as inhibition, in the whole organism at one dose (the size of the read-out at that dose, not a potency): 12.6%
Beside the measured number, compound 3's estimate is 2.6 percentage points below it; the measured number falls inside the stated range.
By their numbers in this assay, from the lowest: compounds 1, 3 and 2 (each within the scatter of the next).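

Placing butyl(methyl)amino where diethylamino stood, on a saturated chain carbon, three bonds along the chain from an oxygen on an aromatic ring, gives in this assay a number 4.8 percentage points higher from compound 1 to compound 3 (within the scatter). Exchanging pyrrolidin-1-yl for the same group at that place gives a number 0.8 percentage points lower from compound 2 to compound 3 (within the scatter), so this position now has three amines, two without a ring and one with a ring, and no step among them stands clear of the scatter; the earlier pair alone offered only a single exchange, whereas the amine at this place has now been varied twice with the same outcome, and for these three compounds the choice among these amines does not separate the readings. Nothing is available beyond these readings that bears on this result.

All three amines sit at the end of the same 3-carbon propyl chain on the shared core, so the compounds shown do not tell whether a morpholin-4-yl or piperidin-1-yl group at this place would give a reading beyond the scatter. They also leave open what a longer chain between the ring oxygen and the amine, or a carboxylic acid in place of the amine, would do in this whole-organism read-out.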